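Swapping the Aryl Group on the Ring Nitrogen

The source may report more compounds than this note shows. Statements on the series, on what has been measured and on what is new or still open speak of the compounds shown alone.

Compound 1 `COc1ccc(-n2cc(CN3C(=O)C[C@@H]4CC[C@@]3(C)C4(C)C)nn2)cc1` gives 70 nM in a functional assay on LoVo cells (Homo sapiens) for inhibition, read by MTT assay, with a stated time of 24 h; a lower number here means a stronger inhibitor, a higher number a weaker inhibitor.
Compound 2 `Cc1ccc(-n2cc(CN3C(=O)C[C@@H]4CC[C@@]3(C)C4(C)C)nn2)cc1` gives 50 nM.
Compound 3 `CC1(C)[C@H]2CC[C@]1(C)N(Cc1cn(-c3cccc(F)c3)nn1)C(=O)C2` gives 90 nM.

Among these three numbers compound 1 stands second highest: it sits near compound 3, with a 1.3-fold higher number from compound 1 to compound 3 (0.11 log units; within the scatter), and near compound 2, with a 1.4-fold lower number from compound 1 to compound 2 (0.15 log units; within the scatter), so all three are within the usual scatter of one another.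

Compound 4 `CC1(C)[C@H]2CC[C@]1(C)N(Cc1cn(-c3ccccc3F)nn1)C(=O)C2` differs from compound 1 by 2-fluorophenyl in place of 4-methoxyphenyl on an aromatic nitrogen. For the measured compounds named here, the steps that bear on it are the related swaps of the aryl group, a 1.3-fold higher number from compound 1 to compound 3 (0.11 log units; within the scatter) and a 1.8-fold higher number from compound 2 to compound 3 (0.26 log units; within the scatter), both within the scatter. A similar outcome is therefore expected here, with no step beyond the scatter: a 1.1-fold higher number from compound 1 to compound 4 (0.06 log units; within the scatter). Compound 4 is estimated at 80 nM, with a range from 35 nM to 180 nM.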

Compound 4, half-maximal inhibitory concentration: 40 nM
Beside the measured number, compound 4's estimate is 2.0-fold (0.30 log units) above it, and the stated range covers the measured number.
By their numbers in this assay, from the lowest: compounds 4, 2, 1 and 3 (each within the scatter of the next, the first and the last beyond it).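

Moving the fluorine on the aryl group gives the first step beyond the scatter in this series in this assay: 2-fluorophenyl in place of 3-fluorophenyl brings a 2.3-fold lower number from compound 3 to compound 4 (0.35 log units; beyond the scatter), so at this ring nitrogen the place of one fluorine can count, if modestly. Compound 4 does not separate from the other two aryl compounds, with a 1.8-fold lower number from compound 1 to compound 4 (0.24 log units; within the scatter) and a 1.3-fold lower number from compound 2 to compound 4 (0.10 log units; within the scatter). Nothing available explains the gap between the two fluorophenyl compounds.

The compounds shown leave open how 4-fluorophenyl, or a phenyl ring carrying an amine or a carboxylic acid, would behave on this nitrogen.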